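Chloro substitution on the benzoyl ring of the quinoline amides

The source may hold more compounds than are shown below. What is called first, only, known or untested is meant among the compounds shown, and "the series" means these compounds.

Measured so far in a functional assay on SK-BR-3 cells (Homo sapiens) for antiproliferative activity, read by MTT assay, with a stated time of 72 h; a higher number here means a weaker inhibitor, a lower number a stronger inhibitor:
- compound 1 `CCN1CCN(c2cc(C)c3cc(NC(=O)c4ccccc4)ccc3n2)CC1`: 18400 nM
- compound 2 `CCNc1cc(C)c2cc(NC(=O)c3ccc(Cl)c(Cl)c3)ccc2n1`: 28200 nM
- compound 3 `Cc1cc(N2CCN(C(C)C)CC2)nc2ccc(NC(=O)c3ccc(Cl)c(Cl)c3)cc12`: 6680 nM

Compound 1 stands second highest of the three numbers. Its value and that of compound 2 lie within the scatter of each other, so no order between them is claimed; compound 3 gives a lower number than compound 1, beyond the scatter.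

Among the measured compounds shown here, the only single-point step measured is a 4.2-fold lower number from compound 2 to compound 3 (0.63 log units; beyond the scatter), which concerns the amine on the core and not the benzoyl ring. Compound 4 `CCN1CCN(c2cc(C)c3cc(NC(=O)c4ccc(Cl)cc4)ccc3n2)CC1` differs from compound 1 by chloro in place of hydrogen on an aromatic carbon. For the measured compounds named here, no measured step isolates this change. Compound 3 carries chlorines on the benzoyl ring and gives a lower number than compound 1, but it also differs in the piperazine substituent, so only a weak lean toward a lower number is supported.

For compound 4 a small step down, likely within the scatter, is expected: a 1.5-fold lower number from compound 1 to compound 4 (0.19 log units; within the scatter). The estimate for compound 4 is 12000 nM, with a range from 5000 nM to 30000 nM.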

Compound 4, half-maximal inhibitory concentration: 3020 nM
For compound 4 the middle estimate is 4.0-fold (0.60 log units) above the measured one; the measured number lies below the stated range.
By their numbers in this assay, from the lowest: compound 4; then compound 3; then compounds 1 and 2 (each within the scatter of the next).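

In this assay, chloro in place of hydrogen on an aromatic carbon of the benzoyl ring, para to a large group, gives a 6.1-fold lower number from compound 1 to compound 4 (0.78 log units; beyond the scatter) with the amine on the core held constant. Among the compounds shown here, this is the first reading of the benzoyl ring on its own, since the earlier comparison with chlorines on that ring also carried a change in the amine, and it shows that a single added heavy atom at this place moves the number beyond the scatter. Nothing at hand accounts for the size of this step.

As far as these compounds go, whether another group at this place, such as fluoro, methoxy or an amine, would give a similar step remains open. Also open, from the compounds shown here alone, is whether a second chlorine adds to the first, since compound 2 and compound 3 carry a different amine on the core.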